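The source may hold more compounds than are shown below. What is called first, only, known or untested is meant among the compounds shown, and "the series" means these compounds.

Of the compounds shown here, two have so far been tested in an ADME assay on HUVEC cells (Homo sapiens) for antiproliferative activity, read by MTT assay, with a stated time of 48 h; on this read-out lower numbers stand for stronger inhibition and higher numbers for weaker inhibition. Compound 1, `CCc1ccccc1-n1nncc1CN1C(=O)C2(C(C#N)=C(N)Oc3c(N)cc4nc5ccccc5nc4c32)c2ccccc21`, gives > 50000 nM there, which is a limit of the assay rather than a number. Compound 2, `COc1ccccc1-n1nncc1CN1C(=O)C2(C(C#N)=C(N)Oc3c(N)cc4nc5ccccc5nc4c32)c2ccccc21`, gives > 50000 nM in this assay, again a limit of the assay. On the numbers shown, compound 2 therefore stands at the limit with no measured value of its own, and the one further value shown is also a limit. The step that the two limits leave unreadable from compound 1 to compound 2 cannot be read, because of the limit of > 50000 nM in this assay, at which 2 of the 2 values shown sit. Compound 3, `N#CC1=C(N)Oc2c(N)cc3nc4ccccc4nc3c2C12C(=O)N(Cc1cnnn1-c1ccc([N+](=O)[O-])cc1)c1ccccc12`, is the next compound to be measured, and it differs from compound 2 in one place: 4-nitrophenyl in place of 2-methoxyphenyl on an aromatic nitrogen. Among the compounds with values here, only the step from compound 1 to compound 2 bears on this change, and its size is not readable, so nothing measured points to a direction or a size in this assay. With both values at the limit, compound 3 is expected to remain there as well, and the estimated step is a number no higher from compound 2 to compound 3 (the limit leaves the size open). The estimate for compound 3 is 50000 nM, with a range from 20000 nM to 150000 nM.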

Compound 3, half-maximal inhibitory concentration: > 50000 nM
Compound 3 ended at the assay's limit (the forecaster's own chance of this, stated with the estimate: 80%); the middle value sits exactly at the limit.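

In this assay, within the data shown here, no step among compound 1, compound 2 and compound 3 can be read, because all three stand at a limit of the assay rather than at a number: the limit of > 50000 nM in this assay, at which 3 of the 3 values shown sit. The compounds shown leave open whether changing the group on the aromatic nitrogen moves the read-out at all, and in which direction.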